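Carbonyl substituent exchange: compound 2 to compound 3

The source may report more compounds than this note shows. Statements on the series, on what has been measured and on what is new or still open speak of the compounds shown alone.

- compound 1 `CN(C(=O)C(C)(C)C)c1ccc2[nH]c(-c3n[nH]c4ccccc34)cc2n1` gives 22200 nM as measured
- compound 2 `CN(C(=O)CCc1ccccc1)c1ccc2[nH]c(-c3n[nH]c4ccccc34)cc2n1` gives 20900 nM as measured

In a functional assay on SMMC-7721 cells (Homo sapiens) for antiproliferative activity, read by MTT assay, with a stated time of 72 h (a lower number here means a stronger inhibitor, a higher number a weaker inhibitor), compound 2 stands level with compound 1 within the scatter. The change to compound 3 `COc1ccc(C(=O)N(C)c2ccc3[nH]c(-c4n[nH]c5ccccc45)cc3n2)cc1` is 4-methoxyphenyl in place of phenethyl on a carbonyl carbon with 4-methoxyphenyl in place of phenethyl on a carbonyl carbon. Within the data shown here, the one measured exchange at that place is a 1.1-fold lower number from compound 1 to compound 2 (0.03 log units; within the scatter) and it stays within the scatter. Among the measured compounds shown here, with only this evidence, no step beyond the scatter is expected in this assay for the new exchange. The estimate amounts to a 1.2-fold lower number from compound 2 to compound 3 (0.06 log units; within the scatter) as an expected step. Compound 3 is estimated at 18000 nM with an expected range of 8000 nM to 40000 nM on this evidence.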

Compound 3, half-maximal inhibitory concentration: 23700 nM
Compound 3: middle estimate off by 1.3-fold (0.12 log units), on the low side; low and high end bracket the measured number.
By their numbers in this assay, from the lowest: compounds 2, 1 and 3 (each within the scatter of the next).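

In this assay the exchange of phenethyl for 4-methoxyphenyl on the carbonyl carbon leaves the number level (a 1.1-fold higher number from compound 2 to compound 3 (0.05 log units; within the scatter)), and the exchange of tert-butyl for 4-methoxyphenyl does too (a 1.1-fold higher number from compound 1 to compound 3 (0.03 log units; within the scatter)). This place on the shared core now holds three groups within the scatter of one another, and the one hydrogen-bond acceptor entering with 4-methoxyphenyl brings no step beyond it. Nothing at hand gives a reason for this flat reading.

Going by these compounds, whether an amine or a carboxylic acid on this carbonyl carbon would move the number beyond the scatter remains open. Exchanges elsewhere on the shared core also remain open.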